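Naphthoquinone sulfonylamidines: from fluorophenyl to nitrophenyl

This account rests on a few compounds, and the source may have more. Where it says the series, first, only, none or still open, it means among the compounds named here.

Measured compounds:
- compound 1, `Cc1ccc(S(=O)(=O)/N=C(/CCNC2=CC(=O)c3ccccc3C2=O)Nc2ccc(Cl)cc2)cc1`: 7080 nM
- compound 2, `Cc1ccc(S(=O)(=O)/N=C(/CCNC2=CC(=O)c3ccccc3C2=O)Nc2ccc(F)cc2)cc1`: 4260 nM

In a functional assay on MCF7 cells (Homo sapiens) for cytotoxicity, read by MTT assay, with a stated time of 48 h (on this read-out lower numbers stand for stronger inhibition and higher numbers for weaker inhibition), compound 2 gives the lowest number of the two shown, and the step of a 1.7-fold lower number from compound 1 to compound 2 (0.22 log units; within the scatter) sits within the scatter. Compound 3, `Cc1ccc(S(=O)(=O)/N=C(/CCNC2=CC(=O)c3ccccc3C2=O)Nc2ccccc2[N+](=O)[O-])cc1`, carries 2-nitrophenyl in place of 4-fluorophenyl on an amine nitrogen. Among the compounds with values here, no measured step covers this change; the only one recorded is the halogen swap, and it was within the scatter. Compound 3 is therefore expected to stay near compound 2, with the step of a 1.2-fold higher number from compound 2 to compound 3 (0.07 log units; within the scatter) no larger than the scatter. The estimate for compound 3 is 5000 nM, between 1500 nM and 16000 nM.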

Compound 3, half-maximal inhibitory concentration: 3090 nM
Beside the measured number, compound 3's estimate is 1.6-fold (0.21 log units) above it; low and high end bracket the measured number.
By their numbers in this assay, from the lowest: compounds 3, 2 and 1 (each within the scatter of the next, the first and the last beyond it).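

In this assay, within the data shown here, placing 2-nitrophenyl on the amine nitrogen gives a 1.4-fold lower number from compound 2 to compound 3 (0.14 log units; within the scatter) and a 2.3-fold lower number from compound 1 to compound 3 (0.36 log units; beyond the scatter), the first step to pass the scatter, though only modestly. This position therefore takes a ring carrying a nitro group, not only a halogen-bearing ring, with no loss in this read-out. No supporting measurement bears on the reason for these steps.

Still open, going by these compounds, is how an unsubstituted phenyl ring, or a ring carrying an amine or a carboxylic acid, would read on this nitrogen.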